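The source may hold more compounds than are shown below. What is called first, only, known or untested is meant among the compounds shown, and "the series" means these compounds.

Compound 1 `Cn1cc(C2CC(c3ccccc3)=NN2C(=O)c2cccnc2)c2cc(Br)ccc21` and compound 2 `COc1ccc2c(c1)c(C1CC(c3ccccc3)=NN1C(=O)c1cccnc1)cn2C` share one core and were both tested in a functional assay on MCF7 cells (Homo sapiens) for inhibition, read by MTT assay, with a stated time of 48 h; on this read-out lower numbers stand for stronger inhibition of growth and higher numbers for weaker inhibition of growth. Compound 1 gives 1520 nM, and compound 2 gives 1160 nM. The change between them, (methoxy in place of bromo on an aromatic carbon), made a 1.3-fold lower number from compound 1 to compound 2 (0.12 log units; within the scatter). Compound 3 `COc1ccc2c(c1)c(C1CC(c3ccc(Br)cc3)=NN1C(=O)c1ccc(OC)nc1)cn2C` rests on a different core; how its core differs from that of compound 1 is not broken down here. In this assay compound 3 gives 6960 nM, which lies beyond the scatter from both compound 1 and compound 2. Compound 4 `COc1ccc(C2=NN(C(=O)c3ccc(OC)nc3)C(c3cn(C)c4ccc(OC)cc34)C2)cc1` has not yet been measured. It differs from compound 3 by methoxy in place of bromo on an aromatic carbon. This is the same kind of change as that between compound 1 and compound 2, but the surroundings differ: in the first pair the carbon belongs to a ring that is part of a fused or bridged system of two rings, meta to a fused ring and para to a fused ring, whereas in compound 4 it sits on a six-membered aromatic ring of carbon only, para to a large group. The earlier step, a 1.3-fold lower number from compound 1 to compound 2 (0.12 log units; within the scatter), was small. On that basis the step to compound 4 is expected to be a 1.3-fold lower number from compound 3 to compound 4 (0.10 log units; within the scatter). In this assay compound 4 is estimated at 5500 nM, between 2500 nM and 12000 nM.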

Compound 4, concentration for 50% growth inhibition: 560 nM
Beside the measured number, compound 4's estimate is 9.8-fold (0.99 log units) above it; measured number outside the range, below it.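

In this assay, methoxy in place of bromo on the six-membered aromatic ring of carbon only, para to a large group, gave a 12-fold lower number from compound 3 to compound 4 (1.09 log units; beyond the scatter), so the change did not carry a single size from one core to the other: the same change on two cores in this assay, a 1.3-fold lower number (0.12 log units; within the scatter) from compound 1 to compound 2 and a 12-fold lower number (1.09 log units; beyond the scatter) from compound 3 to compound 4, 9.5-fold (0.98 log units) apart, beyond the scatter of two such steps This shows that in this series the size of the step cannot be taken from one core and applied to another, since a small step on the core of compound 1 did not predict the large one on the core of compound 3. It does not show what sets the two steps apart, since the pairs differ both in the ring that carries the change and in the rest of the structure, and two pairs cannot separate these.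

The compounds shown leave open how an amine or an ethoxy chain would compare with methoxy at the same place on the core of compound 3. They also leave open whether a 4-methoxyphenyl group would bring a step of similar size on the core of compound 2.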